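A pyridine-to-methoxyphenyl swap on a benzylic amide

The compounds below may be only part of what the source reports. "The series", "measured", "known", "first", "only" and "open" are said of these compounds alone.

Compound 1 `O=C(NCc1ccc(CNS(=O)(=O)c2ccccc2)cc1)c1cccnc1` is measured in an assay on MDA-MB-231 cells for binding affinity to C-X-C chemokine receptor type 4 (Homo sapiens), read by immunofluorescence and microscopy, with stated times of 10 min and 30 min (on this read-out lower numbers stand for an effect already at smaller amounts and higher numbers for an effect only at larger amounts of compound), where compound 1 gives 10 nM. On the numbers shown it stands level with compound 2 `Cc1ccc(S(=O)(=O)NCc2ccc(CNC(=O)c3ccccc3Cl)cc2)cc1`, which in this assay gives 10 nM. Compound 3 `Cc1ccc(S(=O)(=O)NCc2ccc(CNC(=O)c3cccnc3)cc2)cc1` reaches only a limit in this assay, > 1000 nM, as described by the limit of > 1000 nM in this assay, at which 1 of the 3 values shown sits.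

Two single changes lead to compound 3. Adding a methyl in place of hydrogen on an aromatic carbon gives an at least 100-fold higher number from compound 1 to compound 3 (2.00 log units; beyond the scatter). Putting pyridin-3-yl in place of 2-chlorophenyl on a carbonyl carbon gives an at least 100-fold higher number from compound 2 to compound 3 (2.00 log units; beyond the scatter).

Compound 4 `COc1cccc(C(=O)NCc2ccc(CNS(=O)(=O)c3ccccc3)cc2)c1` differs from compound 1 by 3-methoxyphenyl in place of pyridin-3-yl on a carbonyl carbon. The second of those steps bears on this change: in compound 2 a carbon-only ring on the carbonyl carbon went with a low number, while pyridin-3-yl in compound 3 went with a limit. Compound 1 already sits at a low number, so the step to compound 4 is expected to be small, no change at the digits printed from compound 1 to compound 4 (within the scatter). Compound 4 is therefore estimated at 10 nM, between 3 nM and 40 nM.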

Compound 4, effective concentration (reported as EC, without a stated level of effect): > 1000 nM
Compound 4: no number, only a limit; the forecaster's own chance of this, stated with the estimate: 10%; middle value at least 100-fold (2.00 log units) from the limit.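

Placing 3-methoxyphenyl in place of pyridin-3-yl on a carbonyl carbon gives an at least 100-fold higher number from compound 1 to compound 4 (2.00 log units; beyond the scatter), so on the core of compound 1 this position does not accept every ring of carbon only. The earlier step of an at least 100-fold higher number from compound 2 to compound 3 (2.00 log units; beyond the scatter) had pyridin-3-yl on the high side, whereas here it is on the low side, and what pyridin-3-yl does at this position therefore depends on the rest of the molecule or on the ring it is compared with. Compound 4 gives only a limit and no number, and compound 3 stops at that same limit: the limit of > 1000 nM in this assay, at which 2 of the 4 values shown sit.

The compounds shown leave open how 2-chlorophenyl would behave on the core of compound 1, which would test the carbon-only ring directly. They also leave open whether an amine or a carboxylic acid on the ring at the carbonyl carbon would keep a low number.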